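Fluoro to methyl on the aryl ring of a thiazole hydrazone

This account rests on a few compounds, and the source may have more. Where it says the series, first, only, none or still open, it means among the compounds named here.

Measured compounds:
Compound 1 `Clc1ccc(-c2csc(N/N=C/c3cccs3)n2)cc1` gives 86% in a functional assay, read by spectrophotometry, with a stated time of 15 min, tested at 80 ug/mL; a higher number here means a stronger effect of the compound at the concentration tested, a lower number a weaker effect.
Compound 2 `Fc1ccc(-c2csc(N/N=C/c3ccc(Cl)cc3Cl)n2)cc1` gives 94% in this assay.

Of the compounds shown here, two share a core and have been measured. In this assay compound 2 gives 94%, and in the same assay compound 1 gives 86%. Compound 2 carries the larger figure of the two, but the gap to compound 1 lies within the usual scatter of repeated runs, so the two cannot be separated on these numbers. Going by the values given here, no step between measured compounds that differ in only one place is available, so nothing is known about how a single change on the ring bearing the fluoro shifts the read-out.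

Compound 3 `Cc1ccc(-c2csc(N/N=C/c3ccc(Cl)cc3Cl)n2)cc1` has not yet been measured. It differs from compound 2 by methyl in place of fluoro on an aromatic carbon. Among the compounds with values here, with both measured compounds sitting high and close together, and no comparable step to draw on, the change is expected to make no difference beyond the scatter. Compound 3 is therefore estimated to give 90% in this assay, within a range of 75% to 98%. The expected step of a number 4 percentage points lower from compound 2 to compound 3 (within the scatter) is small and within the scatter.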

Compound 3, a percentage reported as inhibition, at one concentration (the size of the read-out at that concentration, not a potency): 84.2%
Estimate against measurement, compound 3: 5.8 percentage points above; the range from low to high includes it.
By their numbers in this assay, from the lowest: compounds 3, 1 and 2 (each within the scatter of the next).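

In this assay, going by these compounds alone, the change from 4-fluorophenyl to 4-methylphenyl, methyl in place of fluoro on an aromatic carbon para to a large group, supplies the first comparison in which only one place differs, and it reads as a number 9.8 percentage points lower from compound 2 to compound 3 (within the scatter). The earlier compounds shown here could say nothing about this ring position on its own, whereas this pair shows that exchanging one heavy atom here for another leaves compound 3 inseparable from compound 2 on these numbers, with the read-out still high for both. No measured property bears on this result, so the data give no account of why the two compounds read alike.

Going by these compounds, whether an amine, a carboxylic acid or a longer chain at this position would move the read-out beyond the scatter remains open. On these data alone, the step also comes from one setting only, the rest of compound 2, so it is unknown whether the same change would read alike on a compound that otherwise matches compound 1.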